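A few compounds are considered here, and "the series" means these few. Any claim that something is new, unique, unknown or untested is made for them only; others in the source may bear on it.

Of the compounds shown here, three on a shared core have been read so far in a functional assay on PC-3 cells (Homo sapiens) for inhibition, read by MTT assay, with a stated time of 48 h, tested at 10 uM (on this read-out higher numbers stand for more inhibition of growth at the one concentration tested and lower numbers for less inhibition of growth), and give low numbers. There compound 1 (`Cc1cc(=O)c2c(O)c(CN3CCCC3)c(O)c([C@H]3CCN(C)C[C@H]3O)c2o1`) gives 10% while compound 2 (`Cc1cc(=O)c2c(O)c(CN3CCN(C(=O)OC(C)(C)C)CC3)c(O)c([C@H]3CCN(C)C[C@H]3O)c2o1`) gives 1% and compound 3 (`CN1CC[C@H](c2c(O)cc(O)c3c(=O)cc(/C=C/c4ccccc4)oc23)[C@H](O)C1`) gives 10% in the same test. Compound 3 therefore stands level with compound 1, and its gap to compound 2 lies within the usual scatter, so the three cannot be ranked against one another.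

Compound 4 (`CN1CC[C@H](c2c(O)cc(O)c3c(=O)cc(/C=C/c4ccccc4F)oc23)[C@H](O)C1`) is compound 3 with a single alteration (fluoro in place of hydrogen on an aromatic carbon). Fluoro takes the place of hydrogen on an aromatic carbon, ortho to a large group, so that the 2-phenylethenyl becomes 2-(2-fluorophenyl)ethenyl. Going by the values given here, no two measured compounds differ in only one place, so the data offer no measured guide to the size of such a change. The expectation therefore rests on compound 3 at 10% alone. The estimated step of a number 2 percentage points higher from compound 3 to compound 4 (within the scatter) is expected to stay within the scatter of this assay and to have no firm direction. Compound 4 is thus expected at 12% with an estimated range from 3% to 28% once it is measured.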

Compound 4, percent growth inhibition at one concentration: 25%
For compound 4 the middle estimate is 13 percentage points below the measured one; low and high end bracket the measured number.
By their numbers in this assay, from the lowest: compounds 2, 1 and 3 (each within the scatter of the next); then compound 4.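

The series now holds its first step between two compounds that differ in one place: in this assay, fluoro in place of hydrogen on an aromatic carbon, ortho to a large group, gives a number 15 percentage points higher from compound 3 to compound 4 (beyond the scatter). Going by these compounds alone, this shows that the phenyl of the 2-phenylethenyl group is a place where a single added atom can move the read-out beyond the scatter, something the earlier compounds, with no such pair among them, could not show. Nothing measured alongside these compounds speaks to what lies behind the rise.

On these data alone, it stays open whether chloro or methoxy on the same aromatic carbon would give a step of similar size, and whether fluoro on another carbon of that ring would do the same. Also open, as far as these compounds go, is whether a second fluoro on the 2-fluorophenyl group would add to the step, and whether the rise at the one concentration tested would hold at other concentrations.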